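This account rests on a few compounds, and the source may have more. Where it says the series, first, only, none or still open, it means among the compounds named here.

Measured compounds:
- compound 1 `O=C(NCCO)c1ccc2ccc(C(=O)c3ccccc3)c-2cc1` — 6 ug/mL in a physicochemical assay for solubility, with a stated time of 24 h, at pH 4.5; on this read-out lower numbers stand for lower solubility and higher numbers for higher solubility
- compound 2 `CN(C)C(=O)c1cn(C)c2ccccc12` — > 51 ug/mL

Within the data shown here, compound 1 is the only compound here with a definite number in this assay, at 6 ug/mL. Among the measured compounds shown here, compound 2 gives > 51 ug/mL, and this is a limit of the assay rather than a measured number, so it shows only that compound 2 sits at the limit of > 51 ug/mL in this assay, at which 1 of the 2 values shown sits. For the measured compounds named here, with one number and one limit, no step between measured compounds can be read, and nothing can be said of how far apart the two compounds truly lie.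

The unmeasured compound 3 `COC(=O)c1ccc2ccc(C(=O)c3ccccc3)c-2cc1` shares the core of compound 1 and differs from it in one place: methoxy in place of (2-hydroxyethyl)amino on a carbonyl carbon. This removes the two hydrogen-bond donors that compound 1 carries in the (2-hydroxyethyl)amino group and leaves a smaller methoxy group in their place.

Starting from compound 1 at 6 ug/mL, compound 3 is expected to move downward by a 3.0-fold lower number from compound 1 to compound 3 (0.48 log units; beyond the scatter), a step beyond the usual scatter. Compound 3 is therefore estimated at 2 ug/mL, with a likely range from 0.5 ug/mL to 8 ug/mL.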

Compound 3, solubility: < 1 ug/mL
Compound 3: a limit, no number; the forecaster's own chance of this, stated with the estimate: 20%; at least 2.0-fold (0.30 log units) between middle value and limit.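

In this assay, among these compounds, putting methoxy in place of (2-hydroxyethyl)amino on the carbonyl carbon gives an at least 6.0-fold lower number from compound 1 to compound 3 (0.77 log units; beyond the scatter), the first step in this set that can be read. This shows that the number at this place depends on what is attached to the carbonyl carbon, a point that compound 1 alone could not show. Compound 3 stands at a limit of the assay rather than at a definite number, so the step has a smallest size but no known true size: the limit of < 1 ug/mL in this assay, at which 1 of the 3 values shown sits.

Among the compounds shown here, the change removes the hydrogen-bond donors of the (2-hydroxyethyl)amino group and shortens the group in the same move, so this single pair cannot tell which of these differences goes with the lower number, and no step to compound 2 can be read. A 2-hydroxyethyl ester, which would keep the hydroxyl on the chain without the amide hydrogen, a plain methylamide, which would keep the amide hydrogen without the hydroxyl, or a carboxylic acid at the same carbonyl carbon would each separate these differences further.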